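The compounds below may be only part of what the source reports. "The series", "measured", "known", "first", "only" and "open" are said of these compounds alone.

Measured compounds:
- compound 1 `CCCS(=O)(=O)Nc1ccc(F)c(C(=O)c2n[nH]c3ncc(-c4ccc(S(=O)(=O)NC)cc4)cc23)c1F`: 14%
- compound 2 `CCCS(=O)(=O)Nc1ccc(F)c(C(=O)c2n[nH]c3ncc(-c4ccc(S(=O)(=O)NCC)cc4)cc23)c1F`: 41%
- compound 3 `CCCS(=O)(=O)Nc1ccc(F)c(C(=O)c2n[nH]c3ncc(-c4ccc(S(=O)(=O)NC(C)=O)cc4)cc23)c1F`: 0.5%

All three share one core and differ only in the group on the sulfonamide nitrogen. In an assay for binding affinity to dual specificity mitogen-activated protein kinase kinase 4 (Homo sapiens), read by KINOMEscan, tested at 10 nM (a lower number here means a stronger effect, a higher number a weaker effect of the compound at the concentration tested), compound 3 stands lowest of the three, so it binds most strongly at the tested concentration. Its nearest neighbour is compound 1, with a number 13.5 percentage points lower from compound 1 to compound 3 (beyond the scatter), and furthest is compound 2, with a number 40.5 percentage points lower from compound 2 to compound 3 (beyond the scatter). Within the measured set, a number 27 percentage points higher from compound 1 to compound 2 (beyond the scatter) shows that even a small change at this nitrogen moves the read-out beyond the scatter.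

Compound 4 `CCCS(=O)(=O)Nc1ccc(F)c(C(=O)c2n[nH]c3ncc(-c4ccc(NS(C)(=O)=O)cc4)cc23)c1F` differs from compound 3 by methanesulfonamido in place of acetylsulfamoyl on an aromatic carbon. Among the measured compounds shown here, none of the measured steps reverses the sulfonamide in this way; they only exchange the group on its nitrogen, so no step bears directly on the change, and the direction is uncertain. Because compound 3 gives 0.5% and compound 1, which also carries a single methyl, gives 14%, compound 4 is expected to lie somewhat higher than compound 3, an estimated a number 19.5 percentage points higher from compound 3 to compound 4 (beyond the scatter). Compound 4 is therefore expected at 20%, within 3% to 55%.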

Compound 4, a percentage reported as activity, at one concentration (the size of the read-out at that concentration, not a potency): 16%
Estimate against measurement, compound 4: 4 percentage points above; low and high end bracket the measured number.
By their numbers in this assay, from the lowest: compound 3; then compounds 1 and 4 (each within the scatter of the next); then compound 2.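

In this assay, attaching the group to the aromatic carbon through its nitrogen rather than its sulfur leaves compound 4 indistinguishable from the methylsulfamoyl compound (a number 2 percentage points higher from compound 1 to compound 4 (within the scatter)). The acetylsulfamoyl compound still binds more strongly (a number 15.5 percentage points higher from compound 3 to compound 4 (beyond the scatter)), while the ethylsulfamoyl compound binds more weakly (a number 25 percentage points lower from compound 2 to compound 4 (beyond the scatter)). Reversing the sulfonamide therefore keeps the read-out within the range already spanned by the three sulfamoyl groups, and how it compares depends on which of those groups it replaces. Nothing shown here explains these differences.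

On these data alone, it remains open whether a longer chain on the sulfonyl sulfur, as in ethanesulfonamido, would shift the number as the ethyl group did in compound 2. A plain amine or a carboxylic acid on this aromatic carbon is also untested among the compounds shown.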